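Acylguanidine chain length at the histamine H2 receptor

The source may report more compounds than this note shows. Statements on the series, on what has been measured and on what is new or still open speak of the compounds shown alone.

Measured so far:
Compound 1, `N/C(=N\C(=O)CCc1c[nH]c2ccccc12)NCCCc1c[nH]cn1`, 81.3 nM
Compound 2, `CCC(=O)/N=C(\N)NCCCc1c[nH]cn1`, 372 nM

Both compounds were run in an in vitro assay on Sf9 cells for agonist activity at histamine H2 receptor (Homo sapiens), read by scintillation counting; on this read-out lower numbers stand for an effect already at smaller amounts and higher numbers for an effect only at larger amounts of compound. Going by the values given here, compound 2 gives the highest of the two numbers recorded; the only neighbour, compound 1, gives 81.3 nM, a lower number by a margin beyond the usual scatter. Among the compounds with values here, no pair differing in a single place has been measured, so no step between measured compounds can be quoted.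

Compound 3, `CC(=O)/N=C(\N)NCCCc1c[nH]cn1`, remains to be measured in this assay. It differs from compound 2 by hydrogen in place of methyl on a saturated chain carbon bound to a carbonyl carbon. The shared core is kept; only the acyl group shrinks.

Of the two numbers in hand, the compound with the larger acyl group, compound 1, sits lower and compound 2 higher. On that basis alone, shortening the acyl group further is expected to move the number upward, and the step is estimated as a 2.0-fold higher number from compound 2 to compound 3 (0.30 log units; within the scatter), probably beyond the scatter but of modest size. For compound 3 the expected value in this assay is 750 nM, within a range from 250 nM to 2500 nM.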

Compound 3, half-maximal effective concentration: 724 nM
Compound 3: the middle estimate sits 1.0-fold (0.02 log units) above what was measured; measured number inside the range.
By their numbers in this assay, from the lowest: compound 1; then compounds 2 and 3 (each within the scatter of the next).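

In this assay, going by these compounds alone, the change from propanoyl to acetyl provides the first step between two compounds that differ in one place: a 1.9-fold higher number from compound 2 to compound 3 (0.29 log units; within the scatter), a difference that does not exceed the usual variation between repeated measurements. On a saturated chain carbon bound to a carbonyl carbon, hydrogen in place of methyl therefore cannot be told apart from no change on these numbers, and compound 2 and compound 3 count as equal in this read-out. No supporting data bear on this result, so the pair gives a size for the step and no explanation for it.

Still open, going by these compounds, is whether a butanoyl group or a longer chain, or an amine or a carboxylic acid carried on the acyl chain, would give a step beyond the scatter at this position. Within the data shown here, compound 1, at 81.3 nM, remains tied to the others by no quotable step, so the two acetyl and propanoyl values alone cannot establish any trend with chain length.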